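The compounds below may be only part of what the source reports. "The series", "measured", "known", "first", "only" and "open" are said of these compounds alone.

Compound 3 `Cc1ccc(CS/C(=C/c2ccc(O)cc2)C(=O)c2ccc(Cl)cc2)cc1` gives 10000 nM in a functional assay on DU-145 cells (Homo sapiens) for inhibition, read by trypan blue exclusion, with a stated time of 96 h; on this read-out higher numbers stand for weaker inhibition of growth and lower numbers for stronger inhibition of growth. Compound 2 `O=C(/C(=C\c1ccc(Cl)cc1)SCc1ccc(F)cc1)c1ccc(Cl)cc1` gives 10000 nM in this assay, level with compound 3 at the digits shown, and the two together stand at the highest number of the three. Compound 1 `Cc1ccc(CS/C(=C/c2c[nH]c3ccc(Cl)cc23)C(=O)c2ccc(Cl)cc2)cc1` gives 1000 nM, the lowest number of the set. Going by the values given here, the only single-place step among the measured compounds, a 10-fold higher number from compound 1 to compound 3 (1.00 log units; beyond the scatter), concerns 4-hydroxyphenyl in place of 5-chloro-1H-indol-3-yl on a double-bonded chain carbon and does not touch the exchange now considered.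

Compound 4 `Cc1ccc(CS/C(=C/c2ccc(Cl)cc2)C(=O)c2ccc(Cl)cc2)cc1` differs from compound 3 by chloro in place of hydroxy on an aromatic carbon, para to a large group. Among the compounds with values here, no measured step covers this exchange directly. Compound 2 carries the same 4-chlorophenyl group on a different benzyl thioether, and its number in this assay is 10000 nM. Compound 4 is therefore expected to show a step of a 1.3-fold lower number from compound 3 to compound 4 (0.10 log units; within the scatter), within the scatter. Compound 4 is estimated at 8000 nM, with a range of 2500 nM to 25000 nM.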

Compound 4, concentration for 50% growth inhibition: 10000 nM
For compound 4 the middle estimate is 1.3-fold (0.10 log units) below the measured one, and the stated range covers the measured number.
By their numbers in this assay, from the lowest: compound 1; then compounds 2, 3 and 4 (each within the scatter of the next).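

In this assay, chloro in place of hydroxy on an aromatic carbon, para to a large group, gives no change at the digits printed from compound 3 to compound 4 (within the scatter), so this exchange separates nothing at this position when the 4-substituted phenyl group is present. Methyl in place of fluoro on the aromatic carbon of the benzyl thioether likewise gives no change at the digits printed from compound 2 to compound 4 (within the scatter). The one clear separation remains at the double-bonded chain carbon, where 4-chlorophenyl in place of 5-chloro-1H-indol-3-yl gives a 10-fold higher number from compound 1 to compound 4 (1.00 log units; beyond the scatter), a step of the same size as a 10-fold higher number from compound 1 to compound 3 (1.00 log units; beyond the scatter).

Nothing presented explains the absence of a change between hydroxy and chloro or the separation of compound 1 from the others. From the compounds shown here alone, whether an amine or a carboxylic acid at this position of the phenyl ring would move the number remains open, as does whether chloro on the indole of compound 1 contributes to its lower number.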